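The source may hold more compounds than are shown below. What is called first, only, known or untested is meant among the compounds shown, and "the series" means these compounds.

Compound 2 `Cn1c(-c2cc(-c3ccc(F)cc3F)ccc2O)n[nH]c1=S` carries a shared core that also appears in compound 1 `Cc1ccc(-n2c(-c3cc(-c4ccc(F)cc4F)ccc3O)n[nH]c2=S)cc1` and compound 3 `Oc1ccc(-c2ccc(F)cc2F)cc1-c1n[nH]c(=S)n1-c1ccccc1`. In a functional assay on the whole organism (strain BALB/c) for inhibition, with Mus musculus as the target, read by paw edema, with a stated time of 4 h, at a dose of 50 mg/kg by the oral route (on this read-out higher numbers stand for more inhibition at the one dose given (going by the name of the read-out) and lower numbers for less inhibition), compound 2 gives 56.9%, the highest of the three numbers, while compound 1 gives 51.6% and compound 3 gives 36.3%. Going by the values given here, the gap to compound 1 is within the scatter, so the two cannot be ranked; only the step of a number 20.6 percentage points lower from compound 2 to compound 3 (beyond the scatter) is beyond it. Compound 4 `CNc1nnc(-c2cc(-c3ccc(F)cc3F)ccc2O)s1` has not been measured. It differs from compound 2 in a single place: a group of 7 heavy atoms (3 carbon, 3 nitrogen, 1 sulfur; one five-membered aromatic ring with 3 hetero atoms) in place of a group of 7 heavy atoms (3 carbon, 3 nitrogen, 1 sulfur; one five-membered aromatic ring with 3 hetero atoms), on an aromatic carbon. Among the compounds with values here, no measured step rebuilds the five-membered ring in this way; the nearest ones, a number 5.3 percentage points higher from compound 1 to compound 2 (within the scatter) and a number 20.6 percentage points lower from compound 2 to compound 3 (beyond the scatter), only swap the group on an aromatic nitrogen, and they show that a small group there sits with the higher numbers. Since the change for compound 4 keeps the same atoms and a small methylamino group, the expected step is a number 6.9 percentage points lower from compound 2 to compound 4 (within the scatter), not clearly beyond the scatter in either direction. Compound 4 is therefore estimated at 50%, with a range from 30% to 68%.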

Compound 4, a percentage reported as inhibition, in the whole organism at one dose (the size of the read-out at that dose, not a potency): 45.4%
Compound 4: the middle estimate sits 4.6 percentage points above what was measured, within the range that was stated.
By their numbers in this assay, from the lowest: compounds 3, 4, 1 and 2 (each within the scatter of the next, the first and the last beyond it).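

In this assay, replacing the ring of compound 2 with 5-(methylamino)-1,3,4-thiadiazol-2-yl, which uses the same atoms joined differently, gives a number 11.5 percentage points lower from compound 2 to compound 4 (beyond the scatter). The earlier steps shown here only swapped the group on an aromatic nitrogen, whereas this one shows that the ring on the aromatic carbon, ortho to a hydroxy group, also matters: rearranging its atoms shifts the number even though a small methyl-bearing group stays on the ring. No measurement shown here explains this drop.

The compounds shown leave open how much of the step belongs to the ring itself and how much to its methylamino group, a question that a plain amine or a longer ethylamino chain on the same ring could address. As far as these compounds go, each number also comes from a single dose and time, so how the compounds compare across other doses remains unknown.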